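The source may hold more compounds than are shown below. What is called first, only, known or untested is meant among the compounds shown, and "the series" means these compounds.

Of the compounds shown here, three built on one shared core have been measured in a functional assay on A549 cells (Homo sapiens) for cytotoxicity, read by MTT assay, with a stated time of 72 h; a higher number here means a weaker inhibitor, a lower number a stronger inhibitor. Compound 1 `CN1CCN(CCCCCn2c3c(c4ccccc42)C(=O)c2c[n+]([O-])c4ccccc4c2C3=O)CC1` gives 870 nM. Compound 2 `CC1(C)O[C@@H](CO)[C@H](Cn2cc(Cn3c4c(c5ccccc53)C(=O)c3c[n+]([O-])c5ccccc5c3C4=O)nn2)O1` gives 370 nM. Compound 3 `O=C1c2c[n+]([O-])c3ccccc3c2C(=O)c2[nH]c3ccccc3c21`, which carries hydrogen on the aromatic nitrogen of the core, gives 320 nM. Within the data shown here, the only pair of measured compounds that differ in a single place is compound 1 and compound 3, where the step of a 2.7-fold lower number from compound 1 to compound 3 (0.43 log units; beyond the scatter) is a modest one. The value of compound 2 lies between those of compound 1 and compound 3: its gap to compound 3 is within the scatter, while its gap to compound 1 is beyond it.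

Compound 4 `O=C1c2c[n+]([O-])c3ccccc3c2C(=O)c2c1c1ccccc1n2Cc1cn([C@H]2O[C@H](CO)[C@@H](O)[C@H]2O)nn1` has not yet been measured. Compared with compound 2 the change is 3,4-dihydroxy-5-(hydroxymethyl)oxolan-2-yl in place of (5-(hydroxymethyl)-2,2-dimethyl-1,3-dioxolan-4-yl)methyl on an aromatic nitrogen. Among the measured compounds shown here, no measured step touches this part of the molecule, and the one step that is known, between compound 1 and compound 3, concerns a different nitrogen and was itself modest. On that basis the step of a 1.1-fold higher number from compound 2 to compound 4 (0.03 log units; within the scatter) is expected to stay within the scatter. Compound 4 is therefore estimated to give 400 nM in this assay, with a range from 150 nM to 1100 nM.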

Compound 4, half-maximal inhibitory concentration: 2680 nM
Beside the measured number, compound 4's estimate is 6.7-fold (0.83 log units) below it, outside the stated range (above it).
By their numbers in this assay, from the lowest: compounds 3 and 2 (each within the scatter of the next); then compound 1; then compound 4.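

Among these compounds, on an aromatic nitrogen of a five-membered aromatic ring with 3 nitrogen, the group is not a free choice in this assay: the change from (5-(hydroxymethyl)-2,2-dimethyl-1,3-dioxolan-4-yl)methyl to 3,4-dihydroxy-5-(hydroxymethyl)oxolan-2-yl gives a 7.2-fold higher number from compound 2 to compound 4 (0.86 log units; beyond the scatter) and is the first step measured at this position. The two groups differ together in ring hetero atoms, hydrogen-bond donors and acceptors, and defined stereocentres, and this single step cannot be divided among those differences. No measured evidence is available to explain the step.

The compounds shown leave open whether the higher number goes with the free hydroxyl groups of the entering group, with its ring, or with the way that ring is attached to the nitrogen. Also open, on these data alone, is how other groups on this nitrogen would read, such as the same oxolane with its hydroxyl groups as acetate esters, a simple amine on a longer chain, or a carboxylic acid.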